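The compounds below may be only part of what the source reports. "The series", "measured", "known", "first", "only" and "open" are said of these compounds alone.

Of the compounds shown here, two have numbers so far in an ADME assay on Huh7.5.1 cells (Homo sapiens) for cytotoxicity, read by ATP content, with a stated time of 48 h; a higher number here means that more compound is tolerated, a lower number that less compound is tolerated. Compound 1 `Cc1cc(C)c(-c2nc(CN3CCC(C(=O)NCCCN4C[C@H](C)C[C@H](C)C4)CC3)c(C)o2)c(C)c1` gives 6570 nM, and compound 2 `Cc1ccccc1-c1nc(CN2CCC(C(=O)NCCCN3CC(C)(C)CC(C)(C)C3)CC2)c(C)o1` gives 4380 nM. Compound 2 therefore stands within the usual scatter of compound 1, its nearest and only neighbour on this scale. The next compound to be tested is compound 3 `Cc1ccccc1-c1nc(CN2CCC(C(=O)NCCCN3CCCC(CC(C)C)C3)CC2)c(C)o1`, which has the same atoms as compound 2, joined differently. The change is a group of 10 heavy atoms (9 carbon, 1 nitrogen; one six-membered non-aromatic ring with 1 hetero atom) in place of a group of 10 heavy atoms (9 carbon, 1 nitrogen; one six-membered non-aromatic ring with 1 hetero atom), on a saturated chain carbon, three bonds along the chain from an amide-type nitrogen. The group that enters and the group that leaves are alike in what can be counted, and the remainder of the structure stays as it is.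

Going by the values given here, no measured pair differing in one place is available to show how this assay responds to a change at this position. The expectation therefore rests on compound 2 at 4380 nM, and no step beyond the scatter is expected, in either direction. The expected 1.0-fold higher number from compound 2 to compound 3 (0.01 log units; within the scatter) is correspondingly small. For compound 3 the estimated value is 4500 nM, with an expected range from 2200 nM to 9000 nM.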

Compound 3, half-maximal cytotoxic concentration: 4640 nM
The estimate for compound 3 lay 1.0-fold (0.01 log units) below the measured number; the measured number falls inside the stated range.
By their numbers in this assay, from the lowest: compounds 2, 3 and 1 (each within the scatter of the next).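

Going by these compounds alone, this is the first step that can be read at this position, on a saturated chain carbon, three bonds along the chain from an amide-type nitrogen: with the same atoms joined differently, this assay records a 1.1-fold higher number from compound 2 to compound 3 (0.03 log units; within the scatter). The earlier compounds shown here offered no pair differing in one place, so it is only now visible that this rearrangement of a six-membered non-aromatic ring group with 1 hetero atom, with every counted feature unchanged, does not separate the two compounds on this scale. No measurement at hand bears on the reason for this result.

The compounds shown leave open whether this assay would respond at this position to a group of a different kind, such as a morpholine ring, an open-chain diethylamine or a piperidine ring carrying a carboxylic acid, since the only group exchanged here matches the one it replaces in everything counted. On these data alone, it also remains open whether the same exchange would read alike on the core of compound 1, which differs from compound 2 and compound 3 in more than one place.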